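A few compounds are considered here, and "the series" means these few. Any claim that something is new, unique, unknown or untested is made for them only; others in the source may bear on it.

Working notes on the series. The read-out throughout is a functional assay on the whole organism with Mus musculus as the target; a lower number here means that less compound is needed, a higher number that more compound is needed for the effect. Of the compounds shown here, three carry a number so far. Compound 1 `O=c1oc2cccnc2n1CCCN1CCN(c2ccccc2)CC1` gives 15.5 mg/kg in this assay. Compound 3 `O=c1oc2cccnc2n1CN1CCN(c2ccc(F)cc2)CC1` gives 3.5 mg/kg in this assay. Compound 2 `O=c1oc2cc(Br)cnc2n1CCN1CCN(c2ccccc2)CC1` gives 34.1 mg/kg in this assay, the highest of the three numbers; its gap to compound 1 and its gap to compound 3 both lie beyond the scatter, the latter by far the wider margin.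

The next compound, compound 4 `O=c1oc2cccnc2n1CCN1CCN(c2ccccc2)CC1`, is compound 2 with one change: hydrogen in place of bromo on an aromatic carbon. Going by the values given here, no pair of measured compounds differs in this one place, so the size of the step has no direct precedent here. Compound 4 shares its bromo-free core with compound 1 and compound 3, which show the lower numbers of the set, while its linker length sits between those two. On that basis, and on the value of compound 2 at 34.1 mg/kg, a move toward a lower number is expected, of moderate size and possibly beyond the scatter; the expected step is a 2.8-fold lower number from compound 2 to compound 4 (0.45 log units; beyond the scatter). For compound 4 the estimate is 12 mg/kg, with a range from 4 mg/kg to 35 mg/kg.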

Compound 4, dose for half-maximal effect: 19.4 mg/kg
Compound 4: middle estimate off by 1.6-fold (0.21 log units), on the low side; the measured number falls inside the stated range.
By their numbers in this assay, from the lowest: compound 3; then compounds 1, 4 and 2 (each within the scatter of the next, the first and the last beyond it).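

Hydrogen in place of bromo on this aromatic carbon, two atoms from the ring nitrogen, gives in this assay a 1.8-fold lower number from compound 2 to compound 4 (0.24 log units; within the scatter), and this step lies within the scatter, so the two compounds cannot be told apart on this read-out. Going by these compounds alone, the earlier compounds differ from one another in more than one place and could not isolate this position; this pair does so for the first time, and here the bromo group can be present or absent without a step that exceeds the scatter. That finding holds for this one pair, on the linker and phenyl-bearing piperazine of compound 4, and nothing available explains the size of the step.

As far as these compounds go, it remains open whether other groups on the same aromatic carbon, such as a methoxy group, an amine or a carboxylic acid, would also stay within the scatter of hydrogen. From the compounds shown here alone, it is equally open whether bromo at this position would give a similar step on a longer chain or alongside a fluoro group on the phenyl ring.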